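This account rests on a few compounds, and the source may have more. Where it says the series, first, only, none or still open, it means among the compounds named here.

Measured so far: compound 1 `CCCSc1nc(N/N=C(\C)c2ccccc2O)c2nnn(Cc3ccco3)c2n1`, 5760 nM; compound 2 `CCCSc1nc(N/N=C(\C)c2ccccc2O)c2nnn(Cc3ccccc3Cl)c2n1`, > 64000 nM; compound 3 `CCCSc1nc(N/N=C(\C)c2ccccc2O)c2nnn(Cc3ccccc3)c2n1`, 11100 nM.

In a functional assay on ECa-109 cells (Homo sapiens) for antiproliferative activity, read by MTT assay, with a stated time of 72 h (on this read-out higher numbers stand for weaker inhibition and lower numbers for stronger inhibition), compound 3 gives 11100 nM, the higher of the two numbers shown; compound 1 gives 5760 nM, and the two sit within the scatter of each other (a 1.9-fold higher number from compound 1 to compound 3 (0.28 log units; within the scatter)). The value of compound 2 is a limit of the assay, not a number (the limit of > 64000 nM in this assay, at which 1 of the 3 values shown sits). Within the data shown here, the one step that touches the benzyl ring itself, an at least 5.7-fold lower number from compound 2 to compound 3 (0.76 log units; beyond the scatter), shows that a chloro on an aromatic carbon of that ring pushes the number out to the limit.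

Compound 4 `CCCSc1nc(N/N=C(\C)c2ccccc2O)c2nnn(Cc3ccc(O)cc3)c2n1` differs from compound 3 by hydroxy in place of hydrogen on an aromatic carbon, a change at a different aromatic carbon and with a different group than the chloro of compound 2. Among the measured compounds shown here, no measured step carries this exact change, so the expectation is weak: a step of modest size upward or none beyond the scatter, the step of a 1.3-fold higher number from compound 3 to compound 4 (0.10 log units; within the scatter) being the estimate. Compound 4 is expected at 14000 nM, within 4000 nM to 60000 nM.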

Compound 4, half-maximal inhibitory concentration: 15900 nM
Beside the measured number, compound 4's estimate is 1.1-fold (0.06 log units) below it; low and high end bracket the measured number.
By their numbers in this assay, from the lowest: compounds 1, 3 and 4 (each within the scatter of the next, the first and the last beyond it). At a limit, above all of these: compound 2.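

In this assay, hydroxy is tolerated on the aromatic carbon para to a large group, at least for this single substituent: a 1.4-fold higher number from compound 3 to compound 4 (0.16 log units; within the scatter). The 4-hydroxybenzyl compound also stays clear of the limit reached with the chloro substituent, an at least 4.0-fold lower number from compound 2 to compound 4 (0.60 log units; beyond the scatter), yet it is separated from the furan compound, a 2.8-fold higher number from compound 1 to compound 4 (0.44 log units; beyond the scatter), a gap that compound 3 does not show against compound 1. The value of compound 2 is a limit and not a number: the limit of > 64000 nM in this assay, at which 1 of the 4 values shown sits.

Compound 2 and compound 4 differ in both the group and its ring carbon, so these two changes cannot be separated. Going by these compounds, whether an amine or a carboxylic acid on the same carbon would also leave the number within the scatter of compound 3 remains open.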